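A Methoxy for a Methyl on the Fused Ring

The compounds below may be only part of what the source reports. "The series", "measured", "known", "first", "only" and "open" are said of these compounds alone.

Compound 1 `CCn1c(=O)/c(=C2\Sc3ccc(C)cc3N2C)s/c1=C\c1ccncc1Nc1ccccc1F` gives the lowest of the two numbers recorded in a functional assay on PC-3 cells (Homo sapiens) for inhibition (a lower number here means a stronger inhibitor, a higher number a weaker inhibitor), at 70 nM. Its nearest neighbour, compound 2 `CCn1c(=O)/c(=C2\Sc3ccc(C)cc3N2C)s/c1=C\c1ccncc1Nc1ccccc1Cl`, gives 500 nM in this assay; the step of a 7.1-fold higher number from compound 1 to compound 2 (0.85 log units; beyond the scatter) comes from chloro in place of fluoro on an aromatic carbon. Compound 3 `CCn1c(=O)/c(=C2\Sc3ccc(OC)cc3N2C)s/c1=C\c1ccncc1Nc1ccccc1F` differs from compound 1 at a different place: methoxy in place of methyl on an aromatic carbon. Within the data shown here, no measured step touches this position, and the only step available concerns a change elsewhere in the molecule, so it offers no guide to the size or direction of the present one. Among the measured compounds shown here, with no direct precedent, the change from compound 1 to compound 3 is expected to stay within the scatter of this assay. The half-maximal inhibitory concentration of compound 3 is therefore estimated at 80 nM, within a range from 25 nM to 250 nM, which corresponds to an expected step of a 1.1-fold higher number from compound 1 to compound 3 (0.06 log units; within the scatter).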

Compound 3, half-maximal inhibitory concentration: 100 nM
The estimate for compound 3 lay 1.3-fold (0.10 log units) below the measured number; measured number inside the range.
By their numbers in this assay, from the lowest: compounds 1 and 3 (each within the scatter of the next); then compound 2.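

On the six-membered aromatic ring of the fused system, the position that carries methyl in compound 1 takes methoxy without a difference that this assay can resolve (a 1.4-fold higher number from compound 1 to compound 3 (0.15 log units; within the scatter)). One added oxygen at this place, with its hydrogen-bond acceptor, thus leaves the number within the scatter, whereas the only other single change shown, chloro in place of fluoro (a 7.1-fold higher number from compound 1 to compound 2 (0.85 log units; beyond the scatter)), lies beyond it. Nothing measured here bears on the reason for this result.

The compounds shown leave open whether an amine, a carboxylic acid or a longer chain such as ethoxy would be taken up as readily at this position. They also leave open whether methoxy in place of methyl would give a similar step on the chloro compound, compound 2.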